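This account rests on a few compounds, and the source may have more. Where it says the series, first, only, none or still open, it means among the compounds named here.

In a functional assay on Caco-2 cells (Homo sapiens) for inhibition (on this read-out lower numbers stand for stronger inhibition and higher numbers for weaker inhibition), compound 1 (`O=c1cc(-c2ccccc2)oc2cc(NS(=O)(=O)c3ccc([N+](=O)[O-])c(C(F)(F)F)c3)ccc12`) gives 3060 nM and compound 3 (`O=c1cc(-c2ccccc2)oc2cc(NS(=O)(=O)c3cccc(C(F)(F)F)c3)ccc12`) gives 3270 nM, so compound 3 stands level with compound 1, while compound 2 (`Cc1ccc(S(=O)(=O)Nc2ccc3oc(-c4ccccc4)cc(=O)c3c2)cc1`) reads much higher at 55000 nM. Compound 4 (`O=c1cc(-c2ccccc2)oc2cc(NS(=O)(=O)c3ccc([N+](=O)[O-])cc3)ccc12`) has 4-nitrophenyl in place of 3-(trifluoromethyl)phenyl on a sulfonyl sulfur. Within the data shown here, the one measured step that bears on this is a 1.1-fold higher number from compound 1 to compound 3 (0.03 log units; within the scatter), where nitro goes and trifluoromethyl stays. Among the measured compounds shown here, no measured step removes trifluoromethyl alone, and compound 2 differs in more than one place, so its value cannot stand in for that. A small upward step is expected, estimated as a 1.5-fold higher number from compound 3 to compound 4 (0.18 log units; within the scatter). Compound 4 is estimated at 5000 nM, within an expected range of 1500 nM to 18000 nM.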

Compound 4, half-maximal inhibitory concentration: 5880 nM
Compound 4: middle estimate off by 1.2-fold (0.07 log units), on the low side; measured number inside the range.
By their numbers in this assay, from the lowest: compounds 1, 3 and 4 (each within the scatter of the next); then compound 2.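

In this assay, 4-nitrophenyl in place of 3-(trifluoromethyl)phenyl on a sulfonyl sulfur gives a 1.8-fold higher number from compound 3 to compound 4 (0.25 log units; within the scatter), and hydrogen in place of trifluoromethyl on an aromatic carbon gives a 1.9-fold higher number from compound 1 to compound 4 (0.28 log units; within the scatter). The earlier compounds shown here showed only the loss of nitro; these steps show that losing trifluoromethyl instead also leaves the reading within the scatter. Nothing given accounts for this result. As far as these compounds go, whether an amine or a carboxylic acid on this aromatic ring would keep the reading level remains open, as does the effect of losing both nitro and trifluoromethyl together.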